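The compounds below may be only part of what the source reports. "The series", "measured", "known", "first", "only" and "open" are said of these compounds alone.

Of the compounds shown here, three share one core and have been tested in a functional assay on PANC-1 cells (Homo sapiens) for inhibition, read by MTT assay, with a stated time of 24 h, tested at 10 uM; a higher number here means more inhibition at the concentration tested (going by the name of the read-out), a lower number less inhibition. Compound 1 `COc1ccc(OCCCOc2cc(=O)n(CCCO)c3c2CC(C/C=C(\C)CCC=C(C)C)C(C)(C)C3)cc1` gives 0% in this assay. Compound 2 `COc1ccc(NC(=O)Oc2cc(=O)n(CCCO)c3c2CC(C/C=C(\C)CCC=C(C)C)C(C)(C)C3)cc1` gives 0%. Compound 3 `CC(C)=CCC/C(C)=C/CC1Cc2c(OC(=O)Nc3ccccc3F)cc(=O)n(CCCO)c2CC1(C)C` gives 0%. The steps between them are all flat: no change at the digits printed from compound 1 to compound 2 (within the scatter), no change at the digits printed from compound 1 to compound 3 (within the scatter) and no change at the digits printed from compound 2 to compound 3 (within the scatter). So compound 3 stands level with compound 1 and compound 2; none of the three shows any inhibition in this assay at the concentration tested.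

The unmeasured compound 4 `CC(C)=CCC/C(C)=C/CC1Cc2c(OC(=O)Nc3ccc(F)cc3F)cc(=O)n(CCCO)c2CC1(C)C` differs from compound 3 in one place: fluoro in place of hydrogen on an aromatic carbon. The new fluoro sits on an aromatic carbon of the six-membered carbon ring, meta to the fluoro already present and para to a large group.

Going by the values given here, no measured step describes adding a fluoro to this ring. The closest information is that exchanging the whole aryl group, as in the step from compound 2 to compound 3, left the value unchanged, and that a far larger exchange, as in the step from compound 1 to compound 3, did the same. Every measured compound is at the floor of the read-out. The step from compound 3 to compound 4 is therefore expected to be no change at the digits printed from compound 3 to compound 4 (within the scatter), no change beyond the scatter. Compound 4 is estimated at 0% in this assay, with a range from 0% to 10%.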

Compound 4, a percentage reported as inhibition, at one concentration (the size of the read-out at that concentration, not a potency): 15.6%
Estimate against measurement, compound 4: 15.6 percentage points below, and the stated range ends below it.
By their numbers in this assay, from the lowest: compounds 1, 2 and 3 (each within the scatter of the next); then compound 4.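

In this assay, going by these compounds alone, placing a fluoro on this aromatic carbon, meta to the fluoro already present and para to a large group, gives a number 15.6 percentage points higher from compound 3 to compound 4 (beyond the scatter), so a change of a single atom at this position moves the read-out off the floor that the earlier compounds all shared. The larger exchanges that end at the same compound show a step of equal size: 2,4-difluorophenyl in place of 4-methoxyphenyl on the amide-type nitrogen gives a number 15.6 percentage points higher from compound 2 to compound 4 (beyond the scatter), and (2,4-difluorophenyl)carbamoyl in place of 3-(4-methoxyphenoxy)propyl gives a number 15.6 percentage points higher from compound 1 to compound 4 (beyond the scatter), whereas the exchange to 2-fluorophenyl alone had shown no movement. Nothing among the data shown explains why this fluoro has this effect.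

Going by these compounds, it remains open whether the gain needs both fluoro groups, which a (4-fluorophenyl)carbamoyl compound would test, and whether a chloro, a methyl or a trifluoromethyl on this same carbon would raise the number as well. Also open, on these data alone, is how compound 4 behaves at other concentrations, since a single-concentration percentage is not a potency.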